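This account rests on a few compounds, and the source may have more. Where it says the series, first, only, none or still open, it means among the compounds named here.

Working notes on the series. The set comprises compound 1 `CC(=O)c1cc(C(=O)c2ccccc2)c(=O)[nH]c1C`, compound 2 `O=C(c1ccccc1)c1cc(C(=O)c2ccccc2)c(=O)[nH]c1-c1ccccc1`, compound 3 `O=C1CCCc2[nH]c(=O)c(C(=O)c3ccccc3)cc21` and the unmeasured compound 4 `O=C1CC(c2ccccc2)Cc2[nH]c(=O)c(C(=O)c3ccccc3)cc21`. In an assay on CHO cells for displacement of a labelled ligand from adenosine receptor A1 (Homo sapiens), tested at 10 uM (on this read-out higher numbers stand for more inhibition at the one concentration tested (going by the name of the read-out) and lower numbers for less inhibition), compound 2 gives 2%, a read-out that does not rise beyond the scatter of the method. In this assay, among the measured compounds shown here, compound 1 gives "not determined" (no result reported) and compound 3 gives "not determined" (no result reported), so compound 3 stands without a number and nothing so far shows appreciable inhibition. Compound 4 differs from compound 3 by phenyl in place of hydrogen on a saturated ring carbon. For the measured compounds named here, since no measured pair shows the effect of this change, and the only number in hand is the low value of compound 2, no step beyond the scatter is expected from compound 3 to compound 4 in this assay. Compound 4 is therefore expected to give about 5%, within -10% to 25%.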

Compound 4, a percentage reported as inhibition, at one concentration (the size of the read-out at that concentration, not a potency): 5%
Compound 4: the middle estimate sits on the measured number at the digits printed; the range from low to high includes it.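

Among the compounds shown here, no step from compound 3 to compound 4 can be read in this assay, since compound 3 has no single number there. The compounds shown leave open what phenyl in place of hydrogen does to inhibition. No measurement in hand bears on a cause for the result.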